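Prenyl ether in place of trifluoroethyl ether on cyclopropane hydrazide

The compounds below may be only part of what the source reports. "The series", "measured", "known", "first", "only" and "open" are said of these compounds alone.

Measured compounds:
compound 1 `O=C(NNc1nncc2ccccc12)C1CC1c1ccc(OCC(F)(F)F)cc1`: 25000 nM
compound 2 `O=C(NNC(=O)C1CC1c1ccc(OCC(F)(F)F)cc1)c1ccncc1`: 19000 nM

In a functional assay on U-373MG ATCC cells (Homo sapiens) for inhibition, read by MTT assay, with a stated time of 72 h (on this read-out higher numbers stand for weaker inhibition and lower numbers for stronger inhibition), compound 1 gives 25000 nM. For the measured compounds named here, compound 2, the only other compound measured here, gives 19000 nM in this assay; the two numbers lie within the usual scatter of each other, so compound 1 cannot be set apart from compound 2 on these data.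

Compound 3 `CC(C)=CCOc1ccc(C2CC2C(=O)NNc2nncc3ccccc23)cc1` has not yet been measured. It differs from compound 1 in one place: 2-methylprop-1-en-1-yl in place of trifluoromethyl on a saturated chain carbon bound to an oxygen on an aromatic ring. Going by the values given here, no measured pair here covers this kind of change, so there is nothing to anchor its size. The change from compound 1 to compound 3 is expected to stay within the scatter, a 1.3-fold lower number from compound 1 to compound 3 (0.10 log units; within the scatter). Compound 3 is therefore estimated at 20000 nM, with a range from 6000 nM to 60000 nM.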

Compound 3, half-maximal inhibitory concentration: 81000 nM
The estimate for compound 3 lay 4.1-fold (0.61 log units) below the measured number; measured number outside the range, above it.
By their numbers in this assay, from the lowest: compounds 2 and 1 (each within the scatter of the next); then compound 3.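

Replacing trifluoromethyl with 2-methylprop-1-en-1-yl on a saturated chain carbon bound to an oxygen on an aromatic ring gives a 3.2-fold higher number from compound 1 to compound 3 (0.51 log units; beyond the scatter) in this assay, a modest step toward weaker inhibition. This position therefore responds to the group it carries, even though both groups have the same heavy-atom count. Nothing available explains the step.

Going by these compounds, whether the double bond or the lost fluorine matters remains open, and a saturated chain such as 3-methylbutyl could separate the two. On these data alone, it is also open whether the same change would carry over to the core of compound 2.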